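Amino in Place of Carboxy: Expected Cytotoxicity Outcome

A few compounds are considered here, and "the series" means these few. Any claim that something is new, unique, unknown or untested is made for them only; others in the source may bear on it.

Measured compounds:
compound 1, `Cc1cc(NC(=O)Nc2ccc(C(=O)O)cc2)c2ccccc2n1`: > 25000 nM
compound 2, `Cc1cc(NC(=O)Nc2ccccc2C(F)(F)F)c2ccccc2n1`: > 25000 nM

Of the compounds shown here, two sharing the same urea core have been tested in an ADME assay on BJ cells (Homo sapiens) for cytotoxicity, with a stated time of 72 h; on this read-out lower numbers stand for an effect already at smaller amounts and higher numbers for an effect only at larger amounts of compound. For compound 1 the result is not a number but a limit, > 25000 nM. For compound 2 the result is likewise a limit, > 25000 nM. Compound 1 therefore stands at the limit of > 25000 nM in this assay, at which 2 of the 2 values shown sit, so there is no number to place it above or below any other compound. Compound 3, `Cc1cc(NC(=O)Nc2ccc(N)cc2)c2ccccc2n1`, differs from compound 1 in one place: amino in place of carboxy on an aromatic carbon. Among the measured compounds shown here, no measured pair shows the effect of such a change, so the expected step that the limit leaves unreadable from compound 1 to compound 3 in this assay is none beyond the scatter. Compound 3 is thus expected to give 30000 nM, with a range from 10000 nM to 100000 nM, most likely again reported only as a limit.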

Compound 3, half-maximal effective concentration: > 25000 nM
Compound 3: a limit, no number; the forecaster's own chance of this, stated with the estimate: 80%; the middle value is on the limit's open side.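

Among the compounds shown here, compound 1 and compound 3 each give only a limit in this assay, so no step between them can be read, and all the values shown coincide: the limit of > 25000 nM in this assay, at which 3 of the 3 values shown sit.

The compounds shown leave open how amino and carboxy compare in this assay, and whether any change to the shared core would give a number there.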